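The source may report more compounds than this note shows. Statements on the series, on what has been measured and on what is new or still open speak of the compounds shown alone.

Compound 1 `O=C(NO)c1ccc(NCc2nc(-c3ccccn3)nn2-c2ccccc2)cc1` carries a hydroxamic acid and a pyridin-2-yl group on the shared core. Going by the values given here, in an assay on Sf9 cells for inhibition of protein deacetylase HDAC6 (Homo sapiens), read by fluorescence, with a stated time of 40 min, tested at 100 nM (on this read-out higher numbers stand for more inhibition at the one concentration tested (going by the name of the read-out) and lower numbers for less inhibition), compound 1 gives 58.6%, the highest of the two numbers measured so far. Compound 2 `CNC(=O)c1ccc(NCc2nc(-c3ccccc3)nn2-c2ccccc2)cc1` differs from it in more than one place, and in this assay compound 2 gives -3.6%; the two values lie far apart, beyond the scatter, but since more than one change separates them, the pair shows only what its two numbers show and no single step can be read from it. Compound 3 `Cc1ccc(-c2nc(CNc3ccc(C(=O)NO)cc3)n(-c3ccccc3)n2)s1` has not yet been measured in this assay. It differs from compound 1 as follows: 5-methylthiophen-2-yl in place of pyridin-2-yl on an aromatic carbon. The hydroxamic acid of compound 1 stays in place; only the aryl group on the aromatic carbon between two ring nitrogen atoms is exchanged. Among the compounds with values here, no step between measured compounds isolates such an exchange, so the expectation rests on compound 1 alone. With the hydroxamic acid kept, the change is expected to be modest, at most a small loss, a step of a number 8.6 percentage points lower from compound 1 to compound 3 (within the scatter). Compound 3 is therefore estimated at 50%, with a range from 25% to 75%.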

Compound 3, a percentage reported as inhibition, at one concentration (the size of the read-out at that concentration, not a potency): 79.7%
Estimate against measurement, compound 3: 29.7 percentage points below; measured number outside the range, above it.
By their numbers in this assay, from the lowest: compound 2; then compound 1; then compound 3.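

With the hydroxamic acid kept, this exchange on the aromatic carbon between two ring nitrogen atoms gives, in this assay, a number 21.1 percentage points higher from compound 1 to compound 3 (beyond the scatter), so this position is not indifferent to the aryl group it carries, something the earlier pair, which differs in more than one place, could not show. The step comes without any change in the counts of heavy atoms, hydrogen-bond donors or hydrogen-bond acceptors, while a six-membered aromatic ring gives way to a five-membered one, ring nitrogen gives way to sulfur, and a methyl group enters. Nothing measured here accounts for the size or direction of this step.

The compounds shown leave open how the step divides among ring size, the sulfur atom and the methyl group, a question that a plain thiophen-2-yl at this position would help to settle. They also leave open whether a longer chain such as ethyl in place of the methyl group of the 5-methylthiophen-2-yl would move the number further in either direction.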